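A few compounds are considered here, and "the series" means these few. Any claim that something is new, unique, unknown or untested is made for them only; others in the source may bear on it.

Compound 1, `CC(C)CN(CC(C)C)S(=O)(=O)c1ccc(NC(=O)C(C)(O)C(F)(F)F)cc1`: > 30000 nM
Compound 2, `CC(O)(C(=O)Nc1ccc(-c2nn[nH]n2)cc1)C(F)(F)F`: > 30000 nM
Compound 3, `CC(O)(C(=O)Nc1ccc([C@@H](O)c2ccccc2)cc1)C(F)(F)F`: > 30000 nM

In an assay on a protein complex (Cavia porcellus) with sulfonylurea receptors; K-ATP channels (Homo sapiens) as the target (on this read-out lower numbers stand for stronger inhibition and higher numbers for weaker inhibition), compound 1 gives > 30000 nM, which is a limit of the assay and not a number. Compound 2 gives > 30000 nM in this assay, again only a limit. Compound 3 gives > 30000 nM in this assay, once more a limit. Compound 3 therefore stands nowhere in particular among the three: all of them sit at the limit of > 30000 nM in this assay, at which 3 of the 3 values shown sit, and the step that the two limits leave unreadable from compound 2 to compound 3 stays unreadable because both of its ends are limits.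

Compound 4, `CN(C)S(=O)(=O)c1ccc(NC(=O)C(C)(O)C(F)(F)F)cc1`, is the next compound to be tested. It differs from compound 3 by dimethylsulfamoyl in place of hydroxy(phenyl)methyl on an aromatic carbon. Among the compounds with values here, none of the measured steps bears on this change, since the one step available is unreadable. What can be said is that compound 1, which carries a related sulfamoyl group on the shared core, also sits at the limit in this assay, as does compound 3. The step this estimate means, a number no higher from compound 3 to compound 4 (the limit leaves the size open), is expected to be none beyond the scatter, with compound 4 most likely reported as a limit again. Compound 4 is therefore estimated to give 30000 nM in this assay, with a range from 10000 nM to 100000 nM.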

Compound 4, half-maximal inhibitory concentration: 480 nM
Beside the measured number, compound 4's estimate is 63-fold (1.80 log units) above it, outside the stated range (below it).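

In this assay, within the data shown here, compound 4 is the first compound here to give a readable number rather than a limit, so this position on the shared core, para to a large group, can clearly influence the result. Placing dimethylsulfamoyl on this aromatic carbon gives an at least 62-fold lower number from compound 3 to compound 4 (1.79 log units; beyond the scatter) and an at least 62-fold lower number from compound 2 to compound 4 (1.79 log units; beyond the scatter), while keeping the sulfonyl and exchanging diisobutylamino for dimethylamino on its sulfur gives an at least 62-fold lower number from compound 1 to compound 4 (1.79 log units; beyond the scatter), so a sulfonyl group alone does not bring the change and the amine attached to it matters as well. The steps among compound 1, compound 2 and compound 3 cannot be read, and each step to compound 4 starts from a limit, which leaves its full size open: the limit of > 30000 nM in this assay, at which 3 of the 4 values shown sit.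

The compounds shown leave open how the number responds to amines of intermediate size on the sulfonyl sulfur, such as diethylamino, or to a ring amine such as piperidine. They also leave open whether the sulfonyl itself is needed, a question that a dimethylamide carbonyl at the same position would address.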